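A Trifluoromethyl Analogue Follows the Chlorophenyl Compound with the Lowest Number

This account rests on a few compounds, and the source may have more. Where it says the series, first, only, none or still open, it means among the compounds named here.

Compound 1 `COc1ccc(-c2cn3ccnc3c(-c3ccc4ncn(C5CCCCC5)c4c3)n2)cc1` gives 82.8% in a functional assay on MOLT-4 cells (Homo sapiens) for inhibition, read by sulforhodamine B assay, with a stated time of 48 h, tested at 10 uM; a higher number here means more inhibition at the concentration tested (going by the name of the read-out), a lower number less inhibition.
Compound 2 `O=Cc1ccc(-c2cn3ccnc3c(-c3ccc4ncn(C5CCCCC5)c4c3)n2)cc1` gives 58.7% in this assay.
Compound 3 `Clc1ccc(-c2cn3ccnc3c(-c3ccc4ncn(C5CCCCC5)c4c3)n2)cc1` gives 8.87% in this assay.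

Compound 3 stands lowest of the three measured numbers, with compound 2 nearest and compound 1 furthest, both separated from it beyond the scatter. The step now followed leads to compound 4 `FC(F)(F)c1cccc(-c2cn3ccnc3c(-c3ccc4ncn(C5CCCCC5)c4c3)n2)c1`, which carries 3-(trifluoromethyl)phenyl in place of 4-chlorophenyl on an aromatic carbon.

Within the data shown here, no measured step exchanges a chloro for a trifluoromethyl or moves a group around the phenyl, so none bears directly on this change. The measured steps show only that the identity of the group on this phenyl moves the read-out strongly: a number 24.1 percentage points lower from compound 1 to compound 2 (beyond the scatter), a number 73.9 percentage points lower from compound 1 to compound 3 (beyond the scatter) and a number 49.8 percentage points lower from compound 2 to compound 3 (beyond the scatter). Because compound 3 gives 8.87%, there is little room for a further fall, and a rise of unknown size is possible. Compound 4 is therefore expected to give 22%, within 0% to 58%, a step of a number 13.1 percentage points higher from compound 3 to compound 4 (beyond the scatter) being the estimate.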

Compound 4, a percentage reported as inhibition, at one concentration (the size of the read-out at that concentration, not a potency): 32.9%
Compound 4: the middle estimate sits 10.9 percentage points below what was measured; low and high end bracket the measured number.
By their numbers in this assay, from the lowest: compound 3; then compound 4; then compound 2; then compound 1.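

In this assay, replacing 4-chlorophenyl with 3-(trifluoromethyl)phenyl gives a number 24 percentage points higher from compound 3 to compound 4 (beyond the scatter) and shows that the lowest number in the series is not the floor for groups at this position. The new group still falls short of the two other groups, with a number 25.8 percentage points lower from compound 2 to compound 4 (beyond the scatter) and a number 49.9 percentage points lower from compound 1 to compound 4 (beyond the scatter) and so takes a place between 4-chlorophenyl and 4-formylphenyl in the order of the four compounds. Nothing available explains why the number moves in this way.

This step changes both the group and its place on the phenyl, and the compounds shown do not separate these two changes. Also open, going by these compounds, is how the number would respond to an amine or a carboxylic acid on this phenyl.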